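The compounds below may be only part of what the source reports. "The series", "measured", "known", "first", "only" and "open" are said of these compounds alone.

Measured compounds:
compound 1, `O=C(NCCCCCCn1c(-c2ccccc2)cc2ccccc21)Oc1ccccc1`, in an assay on microsomes from brain (strain Sprague-Dawley) for inhibition of Fatty-acid amide hydrolase 1 (Rattus norvegicus), read by fluorescence and HPLC, with stated times of 10 min and 60 min (a lower number here means a stronger inhibitor, a higher number a weaker inhibitor), compound 1 gives 520 nM;
compound 2, `O=C(NCCCCCCn1cnc2ccccc21)Oc1ccccc1`, compound 2 gives 290 nM;
compound 3, `O=C(NCCCCCCn1c(-c2ccccc2)c(-c2ccccc2)c2ccccc21)Oc1ccccc1`, compound 3 gives 4700 nM.

Compound 3 stands at the highest number of the three, so it is the weakest inhibitor in this set: compound 1 lies a 9.0-fold higher number from compound 1 to compound 3 (0.96 log units; beyond the scatter) away, and the value of compound 2 is lower still. That single step from compound 1 to compound 3 is the only one shown, and it went upward when a phenyl was added on an aromatic carbon of the shared core.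

Compound 4, `O=C(NCCCCCCn1cc(-c2ccccc2)c2ccccc21)Oc1ccccc1`, has not yet been measured. It differs from compound 3 by one change: hydrogen in place of phenyl on an aromatic carbon. For the measured compounds named here, this is the reverse kind of move to the one seen in the step from compound 1 to compound 3, though it strips a different phenyl from the core than the one added there, so no measured pair matches it exactly. Since adding a phenyl raised the number by a 9.0-fold higher number from compound 1 to compound 3 (0.96 log units; beyond the scatter), taking one away is expected to move the number downward, by a step on the order of a 3.1-fold lower number from compound 3 to compound 4 (0.50 log units; beyond the scatter). Compound 4 is therefore estimated at 1500 nM, most likely between 450 nM and 5000 nM.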

Compound 4, half-maximal inhibitory concentration: 4900 nM
Compound 4: middle estimate off by 3.3-fold (0.51 log units), on the low side; low and high end bracket the measured number.
By their numbers in this assay, from the lowest: compounds 2 and 1 (each within the scatter of the next); then compounds 3 and 4 (each within the scatter of the next).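

Removing the phenyl from the aromatic carbon next to the ring nitrogen leaves the reading in this assay unchanged, a 1.0-fold higher number from compound 3 to compound 4 (0.02 log units; within the scatter), so while the other phenyl stays in place, this position tolerates either phenyl or hydrogen without a measurable shift. For the compounds shown here, the earlier compounds could not show this, as their only step concerned the other phenyl of compound 3, and that step was large, a 9.0-fold higher number from compound 1 to compound 3 (0.96 log units; beyond the scatter); the two phenyl groups of compound 3 therefore do not count alike in this assay, and a change at one of them cannot be read across to the other. Nothing given here explains why the two phenyl groups differ in this way.

Still open, from the compounds shown here alone, is what the shared core would give with hydrogen on both of these carbons, which would show whether the phenyl next to the ring nitrogen matters once the other phenyl is gone. Also open, going by these compounds, is whether a methyl or an amine on the carbon next to the ring nitrogen would read the same as phenyl and hydrogen do here.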